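The source may hold more compounds than are shown below. What is called first, only, known or untested is meant among the compounds shown, and "the series" means these compounds.

Working notes on the series. The compounds share one core; compound 1 `COc1ccc(Nc2nc(SCc3cn(Cc4ccccc4Cl)nn3)nc(-c3ccccc3)c2C#N)cc1` carries a 4-methoxyphenyl on the ring nitrogen, compound 2 `N#Cc1c(Nc2ccccc2F)nc(SCc2cn(Cc3ccccc3Cl)nn2)nc1-c1ccccc1` a 2-fluorophenyl, and compound 3 `N#Cc1c(Nc2ccccc2)nc(SCc2cn(Cc3ccccc3Cl)nn2)nc1-c1ccccc1` an unsubstituted phenyl. In a functional assay on ECa-109 cells (Homo sapiens) for inhibition, read by MTT assay, with a stated time of 72 h (a higher number here means a weaker inhibitor, a lower number a stronger inhibitor), compound 1 gives 7960 nM and compound 2 gives 23000 nM. In this assay compound 3 reaches only the assay limit, > 64000 nM, so that it stands at the weak end of the numbers shown and only a bound is known for it (the limit of > 64000 nM in this assay, at which 1 of the 3 values shown sits). Both steps onto compound 3 raise the number: an at least 8.0-fold higher number from compound 1 to compound 3 (0.90 log units; beyond the scatter) and an at least 2.7-fold higher number from compound 2 to compound 3 (0.44 log units; beyond the scatter).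

Compound 4 `Cc1ccc(Nc2nc(SCc3cn(Cc4ccccc4Cl)nn3)nc(-c3ccccc3)c2C#N)cc1` differs from compound 3 by methyl in place of hydrogen on an aromatic carbon. The step bearing most on this is an at least 8.0-fold higher number from compound 1 to compound 3 (0.90 log units; beyond the scatter) read in reverse, where a group entering in place of hydrogen went with a lower number; a methyl is expected to act in the same direction, though with less confidence, so a modest decrease in this assay is expected, an at least 3.2-fold lower number from compound 3 to compound 4 (0.50 log units; beyond the scatter). Compound 4 is therefore estimated at 20000 nM in this assay, with a range from 6000 nM to 64000 nM.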

Compound 4, half-maximal inhibitory concentration: > 64000 nM
Compound 4 ended at the assay's limit (the forecaster's own chance of this, stated with the estimate: 25%); middle value at least 3.2-fold (0.50 log units) away from the limit.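

In this assay compound 4 stands at a limit of the assay (> 64000 nM), which is not a number. Among the groups shown on this aromatic carbon, the lower number goes with methoxy and not with just any group in place of hydrogen, as methyl does not carry it over (an at least 8.0-fold higher number from compound 1 to compound 4 (0.90 log units; beyond the scatter)), and the 4-methylphenyl compound also falls behind the 2-fluorophenyl one (an at least 2.7-fold higher number from compound 2 to compound 4 (0.44 log units; beyond the scatter)). The step between compound 3 and compound 4 cannot be read, and the two now share the limit: the limit of > 64000 nM in this assay, at which 2 of the 4 values shown sit.

On these data alone, whether ethoxy, hydroxyl or an amine on the same carbon would keep the lower number of compound 1 stays open. As far as these compounds go, how far compound 3 and compound 4 lie past the limit, and so any effect of methyl itself, also stays open.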